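A few compounds are considered here, and "the series" means these few. Any claim that something is new, unique, unknown or untested is made for them only; others in the source may bear on it.

In a functional assay on cells (Mast cell, Rattus norvegicus, strain Wistar) for activation, read by fluorescence, with a stated time of 15 min (a lower number here means that less compound is needed, a higher number that more compound is needed for the effect), compound 1 `CCCCCCCCCCCCCCCCCC(=O)OC[C@@H](O)COP(=O)(O)O[C@@H](C)[C@H](N)C(=O)O` gives 2000 nM. Compound 2 `CCCCCCCCCCCCCCCCCC(=O)OC[C@@H](O)COP(=O)(O)OC[C@H](N)C(=O)OC` reads > 10000 nM, which is a limit of the assay and not a number. Compound 3 `CCCCCCCCCCCCCCCCCC(=O)OC[C@@H](O)COP(=O)(O)OC[C@H](NC)C(=O)O` reads > 10000 nM, which is also only a limit. Compound 3 therefore has no numerical position, and the shared ceiling is the limit of > 10000 nM in this assay, at which 2 of the 3 values shown sit.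

Compound 4 `CCCCCCCCCCCCCCCCCC(=O)OC[C@@H](O)COP(=O)(O)O[C@@H]1CCN[C@H]1C(=O)O` differs from compound 3 on an oxygen whose other neighbour is phosphorus: a group of 8 heavy atoms (5 carbon, 1 nitrogen, 2 oxygen; one five-membered non-aromatic ring with 1 hetero atom) in place of a group of 7 heavy atoms (4 carbon, 1 nitrogen, 2 oxygen; no ring), on an oxygen. The new group carries one five-membered non-aromatic ring with 1 hetero atom.

Two measured steps change the group on this same oxygen: an at least 5.0-fold higher number from compound 1 to compound 2 (0.69 log units; beyond the scatter) and an at least 5.0-fold higher number from compound 1 to compound 3 (0.69 log units; beyond the scatter). Among the compounds with values here, both lie beyond the scatter, and both lead away from the only numerical value. The remaining comparison is a step that the two limits leave unreadable from compound 2 to compound 3, so it offers no guide to size. None of these steps introduces a ring, so the expectation is loose. In this assay, no clear gain is expected, and a result at the limit is likely. The expected change is a number no higher from compound 3 to compound 4 (the limit leaves the size open). For compound 4, the estimated value is 10000 nM, with an expected range from 3000 nM to 30000 nM.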

Compound 4, half-maximal effective concentration: > 10000 nM
Compound 4: a limit, no number; the forecaster's own chance of this, stated with the estimate: 65%; the middle value lies on the limit itself.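

In this assay compound 4 gives > 10000 nM, which is a limit and not a number. The only group shown with a five-membered non-aromatic ring on this oxygen therefore does not match compound 1, the step being an at least 5.0-fold higher number from compound 1 to compound 4 (0.69 log units; beyond the scatter), while the steps to compound 4 from compound 2 and from compound 3 cannot be read. Among the groups shown on this oxygen, with or without a ring, only that of compound 1 gives a number, and the rest sit at the ceiling: the limit of > 10000 nM in this assay, at which 3 of the 4 values shown sit.

As far as these compounds go, how far compound 4 lies past the limit, and so whether the ring differs at all from the open groups of compound 2 and compound 3, stays open. Also open, from the compounds shown here alone, is whether a six-membered ring or a methyl group on the five-membered ring would bring a value under the limit.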